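Compound 2 to Compound 4: Methyl Becomes Ethyl

The compounds below may be only part of what the source reports. "The series", "measured", "known", "first", "only" and "open" are said of these compounds alone.

Measured compounds:
compound 1, `Nc1ccccc1NC(=O)/C=C/c1ccc(CSc2ccc(F)cc2)cc1`, in a functional assay on SMMC-7721 cells (Homo sapiens) for antiproliferative activity, read by CCK-8 assay, with a stated time of 72 h (on this read-out higher numbers stand for weaker inhibition and lower numbers for stronger inhibition), compound 1 gives "not determined" (no result reported)
compound 2, `Cc1ccc(SCc2ccc(C(=O)Nc3ccccc3N)cc2)cc1`, in this assay compound 2 gives 3740 nM
compound 3, `Nc1ccccc1NC(=O)/C=C/c1ccc(CSc2cccc3ccccc23)cc1`, in this assay compound 3 gives "not determined" (no result reported)

Among the measured compounds shown here, compound 2 stands as the only compound with a number in this assay; compound 1 and compound 3 have no result there, so nothing can be said of how compound 2 compares with them. Compound 4, `CCc1ccc(SCc2ccc(C(=O)Nc3ccccc3N)cc2)cc1`, has not yet been measured. It differs from compound 2 in one place: methyl in place of hydrogen on a saturated chain carbon bound to an aromatic carbon. For the measured compounds named here, no pair of measured compounds shows what a change of this kind does in this assay, so the expectation rests on compound 2 alone. The small addition of one carbon on a chain of this sort is expected to leave the value close to that of compound 2, with the step of a 1.1-fold lower number from compound 2 to compound 4 (0.03 log units; within the scatter) expected to stay within the scatter. Compound 4 is therefore estimated at 3500 nM, within a range from 1500 nM to 8000 nM.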

Compound 4, half-maximal inhibitory concentration: 1750 nM
For compound 4 the middle estimate is 2.0-fold (0.30 log units) above the measured one; low and high end bracket the measured number.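

In this assay, going from 4-methylphenyl to 4-ethylphenyl gives a 2.1-fold lower number from compound 2 to compound 4 (0.33 log units; beyond the scatter), and this lower number stands for stronger inhibition. Among the compounds shown here, this is the first sign that the position responds to a change at all: methyl in place of hydrogen on this saturated chain carbon bound to an aromatic carbon is accepted, and it brings a modest gain rather than a loss. No measurement shown here accounts for the gain.

For the compounds shown here, with only this one step, it remains open whether the gain would continue with a longer chain such as propyl or butyl, or would stop there. Equally open, on these data alone, is how an amine or a carboxylic acid would fare on the same chain carbon.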